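Bromine position change on the oxazole-linked phenyl ring

The source may hold more compounds than are shown below. What is called first, only, known or untested is meant among the compounds shown, and "the series" means these compounds.

Two members of the series are in hand, sharing one core and differing only in the aryl group attached to the five-membered ring. In a functional assay on MCF7 cells (Homo sapiens) for cytotoxicity, with a stated time of 48 h (a higher number here means a weaker inhibitor, a lower number a stronger inhibitor), compound 1 `N#Cc1ccc(-c2cc(COC(Cc3cn(C4CCN(Cc5ccc([N+](=O)[O-])cc5)CC4)nn3)c3ccc(Br)cc3)on2)cc1` gives 3000 nM. In the same assay compound 2 `O=[N+]([O-])c1ccc(CN2CCC(n3cc(CC(OCc4cc(-c5cccc(Br)c5)no4)c4ccc(Br)cc4)nn3)CC2)cc1` gives 6000 nM. Compound 2 holds the highest of the two numbers, yet the step of a 2.0-fold higher number from compound 1 to compound 2 (0.30 log units; within the scatter) lies within the scatter, so the two values cannot be ordered.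

Compound 3 `O=[N+]([O-])c1ccc(CN2CCC(n3cc(CC(OCc4cc(-c5ccccc5Br)no4)c4ccc(Br)cc4)nn3)CC2)cc1` differs from compound 2 by 2-bromophenyl in place of 3-bromophenyl on an aromatic carbon. Within the data shown here, no measured step bears directly on moving the bromine around the phenyl ring; the only step available, a 2.0-fold higher number from compound 1 to compound 2 (0.30 log units; within the scatter), exchanged the aryl group entirely and still stayed within the scatter. On that basis a change no larger than the scatter is expected for no change at the digits printed from compound 2 to compound 3 (within the scatter), in no particular direction. Compound 3 is therefore estimated at 6000 nM in this assay, with a range from 2000 nM to 18000 nM.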

Compound 3, half-maximal inhibitory concentration: 6000 nM
Estimate against measurement, compound 3: no gap at the digits printed; the measured number falls inside the stated range.
By their numbers in this assay, from the lowest: compounds 1, 2 and 3 (each within the scatter of the next).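

In this assay, among these compounds, the step of no change at the digits printed from compound 2 to compound 3 (within the scatter) gives the first direct reading on where the bromine sits on this phenyl ring, and 3-(3-bromophenyl)-1,2-oxazol-5-yl and 3-(2-bromophenyl)-1,2-oxazol-5-yl cannot be told apart in this cell read-out. The second bromophenyl isomer also compares with the 4-cyanophenyl group through the step of a 2.0-fold higher number from compound 1 to compound 3 (0.30 log units; within the scatter) and stays within the scatter, so the values of all three aryl groups at this aromatic carbon, next to the ring nitrogen, cannot be ordered. Nothing at hand beyond the cell values bears on why these three groups read alike.

Open, as far as these compounds go, is whether 4-bromophenyl, an aminophenyl or a carboxyphenyl group, or a saturated group such as cyclohexyl, would give a step beyond the scatter at this carbon. Also open, from the compounds shown here alone, is whether the same indifference to the bromine position would hold with other groups on the shared core, for instance with a hydroxyl or a methoxy group in place of the bromine on the other phenyl ring.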